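The compounds below may be only part of what the source reports. "The series", "measured", "known", "first", "only" and "open" are said of these compounds alone.

Working notes on the series. Compound 1 `CCCCCCCCCCNc1nc(=O)n([C@H]2C[C@H](O)[C@@H](CO)O2)cc1C` and compound 2 `CCCCCCCCCCCCNc1nc(=O)n([C@H]2C[C@H](O)[C@@H](CO)O2)cc1C` share one core; compound 3 `CCCCCCCCNc1ccn([C@@H]2O[C@H](CO)[C@@H](O)[C@H]2O)c(=O)n1` and the still unmeasured compound 4 `CCCCCCCCCCNc1ccn([C@@H]2O[C@H](CO)[C@@H](O)[C@H]2O)c(=O)n1` share another, and the difference between the two cores is not broken down here. In an ADME assay on A549 cells (Homo sapiens) for cytotoxicity, read by MTT assay (on this read-out higher numbers stand for lower toxicity in this test and lower numbers for higher toxicity in this test), compound 1 gives 156000 nM and compound 2 gives 158000 nM; in this assay compound 3 gives 90000 nM, and its values against compound 1 and compound 2 fall within the scatter, so no order among the three is read.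

The change from compound 1 to compound 2 is ethyl in place of hydrogen on a saturated chain carbon, ten or more bonds along the chain from a nitrogen on an aromatic ring, and it made a 1.0-fold higher number from compound 1 to compound 2 (0.01 log units; within the scatter). The change from compound 3 to compound 4 is ethyl in place of hydrogen on a saturated chain carbon, eight bonds along the chain from a nitrogen on an aromatic ring; it is the same kind of change, differing only in its place along the chain, and on the other core. Because the earlier step of a 1.0-fold higher number from compound 1 to compound 2 (0.01 log units; within the scatter) stayed within the scatter, the step from compound 3 to compound 4 in this assay is expected to be about a 1.1-fold higher number from compound 3 to compound 4 (0.02 log units; within the scatter). Compound 4 is accordingly estimated at 95000 nM, expected between 45000 nM and 190000 nM.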

Compound 4, half-maximal cytotoxic concentration: 90000 nM
For compound 4 the middle estimate is 1.1-fold (0.02 log units) above the measured one; the measured number falls inside the stated range.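

In this assay, ethyl in place of hydrogen on the core of compound 3 gives no change at the digits printed from compound 3 to compound 4 (within the scatter), and the same kind of change on the core of compound 1 gives a 1.0-fold higher number from compound 1 to compound 2 (0.01 log units; within the scatter). The two steps agree: the same change on two cores in this assay, a 1.0-fold higher number (0.01 log units; within the scatter) from compound 1 to compound 2 and no change at the digits printed (within the scatter) from compound 3 to compound 4, 1.0-fold (0.01 log units) apart, within the scatter of two such steps

This shows that, for these two pairs, the change leaves the read-out within the scatter on both cores, but it is an agreement between two steps of no readable size, made at different places along the chain. It does not show that a step of readable size would carry from one core to the other, nor does it separate the core from the place along the chain.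

The compounds shown leave open whether a longer chain than that of compound 2, or a chain ending in an amine or a carboxylic acid, would move the number in this assay beyond the scatter. Going by these compounds, whether such a step would then match on both cores also stays open.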